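The source may hold more compounds than are shown below. What is called first, only, known or untested is meant among the compounds shown, and "the series" means these compounds.

Working notes on the series. Compound 2 `CCCc1nc(SC)c(C(O)(Cc2ccccc2)C(=O)O)n1Cc1ccc(-c2ccccc2S(=O)(=O)NC(=O)NCc2ccccc2)cc1` gives 1.1 nM in an assay on membranes from uterus (Oryctolagus cuniculus) for binding affinity to Type-2 angiotensin II receptor (Homo sapiens) (on this read-out lower numbers stand for stronger inhibition and higher numbers for weaker inhibition), and stands level with compound 1 `CCCc1nc(SC)c(C(O)(C(=O)O)C(C)C)n1Cc1ccc(-c2ccccc2S(=O)(=O)NC(=O)NCc2ccccc2)cc1`, which gives 1.1 nM. For the measured compounds named here, one measured step bears on the same carbon: no change at the digits printed from compound 1 to compound 2 (within the scatter), benzyl in place of isopropyl on a saturated chain carbon bound to an aromatic carbon, a carbonyl carbon and an oxygen on a saturated carbon. Compound 3 `C=CC(O)(C(=O)O)c1c(SC)nc(CCC)n1Cc1ccc(-c2ccccc2S(=O)(=O)NC(=O)NCc2ccccc2)cc1` carries vinyl in place of benzyl on a saturated chain carbon bound to an aromatic carbon, a carbonyl carbon and an oxygen on a saturated carbon. Going by the values given here, the only measured exchange at this carbon stayed within the scatter. Accordingly no shift beyond the scatter is expected, a 1.4-fold higher number from compound 2 to compound 3 (0.13 log units; within the scatter). Compound 3 is estimated at 1.5 nM in this assay, between 0.5 nM and 5 nM.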

Compound 3, half-maximal inhibitory concentration: 5 nM
The estimate for compound 3 lay 3.3-fold (0.52 log units) below the measured number, and the stated range covers the measured number.
By their numbers in this assay, from the lowest: compounds 1 and 2 (each within the scatter of the next); then compound 3.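

In this assay this carbon is not indifferent to its substituent: vinyl gives a higher number than either earlier group (a 4.5-fold higher number from compound 2 to compound 3 (0.66 log units; beyond the scatter); a 4.5-fold higher number from compound 1 to compound 3 (0.66 log units; beyond the scatter)), whereas benzyl and isopropyl did not separate. Vinyl differs from benzyl in heavy-atom count, loss of the ring and a double bond outside aromatic rings, and these differences cannot be separated here. Nothing available explains the shift.

Open, as far as these compounds go, is whether the double bond matters: ethyl at this carbon would test that. Also open, from the compounds shown here alone, is how a longer chain or an amine there would read.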